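Trimming an Isopropyl to Methyl on a Weak Core

The source may hold more compounds than are shown below. What is called first, only, known or untested is meant among the compounds shown, and "the series" means these compounds.

For the measured compounds named here, compound 1 `CC(C)c1nnc2nnc(N3CCCC3)nn12` is one of two compounds tested in a functional assay on HL-60 cells (Homo sapiens) for cytotoxicity, read by MTT assay, with a stated time of 72 h (on this read-out lower numbers stand for stronger inhibition and higher numbers for weaker inhibition), and holds the only actual number there: in this assay compound 1 gives 71200 nM. For compound 2 `O=[N+]([O-])c1ccc(-c2nnc3nnc(N4CCCC4)n3n2)cc1` the test returned only a limit, > 100000 nM, which is the limit of > 100000 nM in this assay, at which 1 of the 2 values shown sits. Compound 3 `Cc1nnc2nnc(N3CCCC3)nn12` differs from compound 1 by methyl in place of isopropyl on an aromatic carbon. Going by the values given here, no measured pair shows what such a trim does, so the step is expected to stay small, at most a slight weakening, a 1.3-fold higher number from compound 1 to compound 3 (0.10 log units; within the scatter). Compound 3 is therefore estimated at 90000 nM, with a range from 40000 nM to 200000 nM.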

Compound 3, half-maximal inhibitory concentration: 29700 nM
The estimate for compound 3 lay 3.0-fold (0.48 log units) above the measured number, and the stated range ends above it.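

In this assay, the aromatic carbon between two ring nitrogen atoms responds to a trim: methyl in place of isopropyl gives a 2.4-fold lower number from compound 1 to compound 3 (0.38 log units; beyond the scatter). For the compounds shown here, on this shared core, the smaller of these two groups therefore goes with the lower number, a direction no earlier measured pair could show. Nothing measured here explains this step. Going by these compounds, whether the trend would continue with a bare hydrogen at this place remains open. So does what an amine or a longer chain would do there, and even the lower number remains weak.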